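From Hydroxy to Methoxy on Compound 2

The source may hold more compounds than are shown below. What is called first, only, known or untested is meant among the compounds shown, and "the series" means these compounds.

Of the compounds shown here, two have so far been measured in a functional assay on MDA-MB-231 cells (Homo sapiens) for antiproliferative activity, read by MTT assay, with a stated time of 48 h; on this read-out lower numbers stand for stronger inhibition of growth and higher numbers for weaker inhibition of growth. There, compound 1 `CCCOC(=O)N1N=C(c2cccc(O)c2)CC1c1cc(OC)c(OC)c(OC)c1` gives 10000 nM, and compound 2 `COC(=O)N1N=C(c2ccccc2)CC1c1ccc(OC)c(O)c1` gives 14500 nM. These two numbers lie within the usual scatter of each other, so compound 2 stands level with compound 1 on the data available, and neither can be ranked above the other.

Compound 3 `COC(=O)N1N=C(c2ccccc2)CC1c1ccc(OC)c(OC)c1` differs from compound 2 in one place: methyl in place of hydrogen on an oxygen on an aromatic ring. This is methyl in place of hydrogen on an oxygen on an aromatic ring, which turns a hydroxy into a methoxy.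

Among the compounds with values here, no measured pair in this small set isolates that change, and compounds 1 and 2 differ in several places at once. The data therefore offer no direction for the change in this assay, and none beyond the scatter is expected. The expected 1.2-fold lower number from compound 2 to compound 3 (0.08 log units; within the scatter) is small and could fall either way. For compound 3 the estimated value is 12000 nM, with the measurement expected to fall between 5000 nM and 30000 nM.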

Compound 3, concentration for 50% growth inhibition: 8940 nM
For compound 3 the middle estimate is 1.3-fold (0.13 log units) above the measured one; the measured number falls inside the stated range.
By their numbers in this assay, from the lowest: compounds 3, 1 and 2 (each within the scatter of the next).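

In this assay, within the data shown here, this pair gives the first direct reading of methyl in place of hydrogen on an oxygen on an aromatic ring, with a 1.6-fold lower number from compound 2 to compound 3 (0.21 log units; within the scatter) as the step. Compounds 1 and 2 differ in several places at once and could say nothing about this change alone, whereas compound 2 and compound 3 differ only here. On this core, then, hydroxy and methoxy at this position stand level, and the hydrogen on that oxygen can give way to a methyl without a shift that exceeds the scatter. No outside evidence bears on this result, so the step stands as a bare observation.

The compounds shown leave open whether a larger group on the same oxygen, such as an ethyl or an acetyl group, or a longer chain ending in an amine or a carboxylic acid, would also stay level with compound 2 or would move the number beyond the scatter. They also leave open whether hydroxy to methoxy would read the same way at this position on a different background, such as the core of compound 1, where other parts of the molecule differ.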